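This account rests on a few compounds, and the source may have more. Where it says the series, first, only, none or still open, it means among the compounds named here.

Going by the values given here, in a functional assay on HCT-116 cells (Homo sapiens) for inhibition, with a stated time of 72 h (a higher number here means a weaker inhibitor, a lower number a stronger inhibitor), only two compounds have been measured so far. Compound 1 `N#Cc1c[nH]c2c(NS(=O)(=O)c3cccnc3)cccc12` gives 230 nM and compound 2 `Cc1cncc(S(=O)(=O)Nc2cccc3c(C#N)c[nH]c23)c1` gives 190 nM and these two values lie within the scatter of each other. Compound 3 `N#Cc1c[nH]c2c(NS(=O)(=O)c3ccc(N)nc3)cccc12` has not yet been measured. It differs from compound 2 by 6-aminopyridin-3-yl in place of 5-methylpyridin-3-yl on a sulfonyl sulfur and so carries 6-aminopyridin-3-yl in place of 5-methylpyridin-3-yl on a sulfonyl sulfur. Among the compounds with values here, the one measured step that bears on this change is a 1.2-fold lower number from compound 1 to compound 2 (0.08 log units; within the scatter) and it stays within the scatter. That step covers only methyl in place of hydrogen on an aromatic carbon, and no amino group has been measured on the shared core, so it is a limited guide. No step beyond the scatter is therefore expected in this assay and the estimated step is a 1.1-fold higher number from compound 2 to compound 3 (0.02 log units; within the scatter) with wide uncertainty. For compound 3 the estimated value is 200 nM with an expected range from 70 nM to 600 nM in the measurement to come.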

Compound 3, half-maximal inhibitory concentration: 640 nM
Beside the measured number, compound 3's estimate is 3.2-fold (0.51 log units) below it, and the stated range ends below it.
By their numbers in this assay, from the lowest: compounds 2 and 1 (each within the scatter of the next); then compound 3.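

In this assay, going by these compounds alone, the group on a sulfonyl sulfur now shows a change beyond the scatter, which the methyl step between the earlier compounds did not: 6-aminopyridin-3-yl in place of 5-methylpyridin-3-yl gives a 3.4-fold higher number from compound 2 to compound 3 (0.53 log units; beyond the scatter) in this comparison. The added amino group gives a 2.8-fold higher number from compound 1 to compound 3 (0.44 log units; beyond the scatter) as well, so the modest loss appears against both earlier compounds and this position does not accept every small group alike. Nothing available here explains this loss. The compounds shown leave open whether a hydroxyl, a methoxy or a dimethylamino group in place of that amino group would give a number closer to compound 3 or to compound 2. They also leave open how a plain phenyl group on the sulfonyl sulfur would compare.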